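This account rests on a few compounds, and the source may have more. Where it says the series, first, only, none or still open, it means among the compounds named here.

Compound 1, `COc1ccc(-c2ccc(-c3ccc(-c4nc5ccccc5[nH]4)cc3)cc2)cc1`, is the simplest of the three measured compounds; in a functional assay on MCF7 cells (Homo sapiens) for inhibition, read by sulforhodamine B assay (a higher number here means a weaker inhibitor of growth, a lower number a stronger inhibitor of growth), compound 1 gives 33300 nM. Compound 2, `COc1ccc(-c2ccc(-c3ccc(-c4nc5ccccc5[nH]4)cc3)cc2)cc1OC`, carries one further group, described as methoxy in place of hydrogen on an aromatic carbon, and in this assay compound 2 gives 7600 nM. That change made a 4.4-fold lower number from compound 1 to compound 2 (0.64 log units; beyond the scatter). Compound 3, `COc1ccc(-c2ccc(-c3ccc(-c4nc5c(O)cccc5[nH]4)cc3)cc2)cc1OC`, differs from compound 2 by a hydroxy in place of hydrogen on an aromatic carbon, and in this assay compound 3 gives 190 nM, a step of a 40-fold lower number from compound 2 to compound 3 (1.60 log units; beyond the scatter). The difference between the core of compound 1 and the core of compound 3 is not broken down here.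

Compound 4, `COc1cc(-c2ccc(-c3ccc(-c4nc5c(O)cccc5[nH]4)cc3)cc2)cc(OC)c1OC`, has not yet been measured. It differs from compound 3 by methoxy in place of hydrogen on an aromatic carbon, the same kind of change as was made from compound 1 to compound 2, though here the entering group is also meta to a methoxy group. Resting on the size of the step from compound 1 to compound 2, the step to compound 4 is expected to be a 1.9-fold lower number from compound 3 to compound 4 (0.28 log units; within the scatter). Compound 4 is therefore estimated at 100 nM in this assay, between 30 nM and 400 nM.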

Compound 4, concentration for 50% growth inhibition: < 100 nM
Compound 4: no number, only a limit; the forecaster's own chance of this, stated with the estimate: 2%; the middle value lies on the limit itself.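

In this assay compound 4 gives < 100 nM, which is a limit of the assay and not a number. The methoxy in place of hydrogen can therefore be read only as an at least 1.9-fold lower number from compound 3 to compound 4 (0.27 log units; that floor lies within the scatter), so the result goes neither against the earlier step nor shows on its own a change beyond the usual scatter. Whether the change is worth the same on both cores stays undecided, and the series shows only that a second methoxy-for-hydrogen step on the core of compound 3 did not leave the value above the limit: the same change on two cores in this assay, a 4.4-fold lower number (0.64 log units; beyond the scatter) from compound 1 to compound 2 and an at least 1.9-fold lower number (0.27 log units; that floor lies within the scatter) from compound 3 to compound 4; the limit leaves it open whether they differ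

The compounds shown leave open how far the true value of compound 4 lies past its limit, and so how large the step on this core really is. They also leave open whether an ethoxy group, a fluorine atom or an amine at the same place would read any differently from methoxy, and whether the hydroxy group gives a similar step on the core of compound 1 or compound 4 without the methoxy groups.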